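Chloro in Place of Nitro, Repeated on a Second Core

The compounds below may be only part of what the source reports. "The series", "measured", "known", "first", "only" and "open" are said of these compounds alone.

Of the compounds shown here, three have been measured in an ADME assay on Vero cells (Chlorocebus sabaeus) for cytotoxicity, read by MTT assay, with a stated time of 72 h; a lower number here means a stronger inhibitor, a higher number a weaker inhibitor. Compound 1 `O=C(NNC(=O)c1ccc([N+](=O)[O-])cc1)c1ccc(-n2cccc2)cc1` gives 190000 nM in this assay. Compound 3 `O=C(NNC(=O)c1ccc(-n2cccc2)cc1)c1ccc(Cl)cc1` gives 179000 nM, and compound 2 `O=[N+]([O-])c1ccc(-c2nnc(-c3ccc(-n4cccc4)cc3)o2)cc1` gives 258000 nM. The values of compounds 1, 2 and 3 all lie within the scatter of one another, so no order among them can be read from these numbers.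

Compound 1 and compound 3 share one core and differ at a single place: chloro in place of nitro on an aromatic carbon. The measured step is a 1.1-fold lower number from compound 1 to compound 3 (0.03 log units; within the scatter), a change that did not move the number beyond the scatter. Compound 2 carries a different core; how the core of compound 2 differs from the core of compound 1 is not broken down here.

Compound 4 `Clc1ccc(-c2nnc(-c3ccc(-n4cccc4)cc3)o2)cc1` has not yet been measured. It stands to compound 2 exactly as compound 3 stands to compound 1: chloro in place of nitro on an aromatic carbon. Among the measured compounds shown here, the two place descriptions agree word for word, so this is the same change made on a second core, and it is the only precedent available. For the measured compounds named here, on that basis the step from compound 2 to compound 4 is expected to be small, close to a 1.1-fold lower number from compound 1 to compound 3 (0.03 log units; within the scatter), namely a 1.1-fold lower number from compound 2 to compound 4 (0.04 log units; within the scatter), because a 1.1-fold lower number from compound 1 to compound 3 (0.03 log units; within the scatter) is the only measured example of this change. Compound 4 is therefore estimated at 235000 nM in this assay, with an expected range from 150000 nM to 400000 nM.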

Compound 4, half-maximal inhibitory concentration: 253000 nM
Estimate against measurement, compound 4: 1.1-fold (0.03 log units) below; measured number inside the range.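

The new step in this assay is a 1.0-fold lower number from compound 2 to compound 4 (0.01 log units; within the scatter) and, like the earlier step, it stays within the scatter, so chloro in place of nitro on an aromatic carbon gives the same result on both cores: (the same change on two cores in this assay, a 1.1-fold lower number (0.03 log units; within the scatter) from compound 1 to compound 3 and a 1.0-fold lower number (0.01 log units; within the scatter) from compound 2 to compound 4, 1.0-fold (0.02 log units) apart, within the scatter of two such steps). For these two pairs, then, the earlier step carried over from the core of compound 1 to the core of compound 2, and the change left the number within the scatter on each. This does not show that a change with a larger step would carry over in the same way, since neither pair has a step beyond the scatter, and two pairs cannot establish a rule for the whole series or for any other core.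

The compounds shown hold only nitro or chloro at this place, so it remains open whether an amine, a carboxylic acid or a longer chain there would move the number in this assay beyond the scatter. Going by these compounds, it also remains open whether the same swap would leave the number within the scatter on a third core, or at another place on the same aromatic ring.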